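The source may report more compounds than this note shows. Statements on the series, on what has been measured and on what is new or still open speak of the compounds shown alone.

Compound 1 `COc1cc(-c2cc(/C=C/C(=O)c3ccc(Cl)c(Cl)c3)[nH]n2)cc(OC)c1OC` is measured in a functional assay on NCI-H226 cells (Homo sapiens) for cytotoxicity, read by sulforhodamine B assay, with a stated time of 48 h, tested at 0.1 uM (a higher number here means a weaker effect of the compound at the concentration tested, a lower number a stronger effect), and gives 103%, the highest of the three numbers at hand. Compound 2 `COc1ccc(-c2cc(/C=C/C(=O)c3ccc(N)cc3)[nH]n2)cc1OC` in this assay gives 91%, and compound 3 `COc1ccc(-c2cc(/C=C/C(=O)c3ccc(N)cc3)[nH]n2)cc1` in this assay gives 84%. Compound 1 thus stands above compound 2 and further above compound 3, and both gaps lie beyond the scatter. Going by the values given here, the only step between two measured compounds that differ in one place is a number 7 percentage points lower from compound 2 to compound 3 (within the scatter); it lies within the scatter and concerns a hydrogen in place of a methoxy on an aromatic carbon, not the ring on the carbonyl carbon.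

Compound 4 `COc1ccc(C(=O)/C=C/c2cc(-c3cc(OC)c(OC)c(OC)c3)n[nH]2)cc1OC` has not yet been measured in this assay. It differs from compound 1 by 3,4-dimethoxyphenyl in place of 3,4-dichlorophenyl on a carbonyl carbon. Among the compounds with values here, no measured step bears on an exchange of this kind, since compounds 2 and 3 each carry a different ring on the carbonyl carbon and sit more than one change away from compound 1. Within the data shown here, the single known step is within the scatter, which gives no ground to expect a large move. Compound 4 is therefore expected to show a number 8 percentage points lower from compound 1 to compound 4 (within the scatter), a step that need not pass beyond the scatter. Compound 4 is estimated at 95%, with a range from 80% to 107%.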

Compound 4, a percentage reported as activity, at one concentration (the size of the read-out at that concentration, not a potency): 97%
For compound 4 the middle estimate is 2 percentage points below the measured one; low and high end bracket the measured number.
By their numbers in this assay, from the lowest: compounds 3, 2, 4 and 1 (each within the scatter of the next, the first and the last beyond it).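

In this assay, going by these compounds alone, the exchange of 3,4-dichlorophenyl for 3,4-dimethoxyphenyl on a carbonyl carbon comes with a number 6 percentage points lower from compound 1 to compound 4 (within the scatter) and is the first measured step at this position, which no earlier pair of compounds could show. Both groups are six-membered aromatic rings of carbon only, but the entering group carries hydrogen-bond acceptors and the leaving group carries none, so on this core that difference does not separate the two compounds beyond the usual scatter of this read-out at the single concentration tested. Nothing at hand explains this outcome or bears on what either group does in the cells.

On these data alone, whether a group of another kind on this ring, such as a carboxylic acid or a trifluoromethyl, or a longer chain in place of the ring on the carbonyl carbon, would move the number beyond the scatter remains open. Also open, as far as these compounds go, is whether the same exchange would give a similar step on a core other than that of compound 1, or at a higher concentration.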